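The source may report more compounds than this note shows. Statements on the series, on what has been measured and on what is new or still open speak of the compounds shown alone.

Compound 1 `COc1cc(C2=NN(C(=O)c3ccccc3)C(c3ccccc3)C2)ccc1O`: 41100 nM
Compound 2 `COc1cc(C2=NN(C(=S)Nc3ccccc3)C(c3ccccc3)C2)ccc1O`: 15900 nM

Both compounds were tested in an assay on isolated protein for inhibition of Amine oxidase [flavin-containing] B (Homo sapiens), read by Amplex Red, with a stated time of 15 min; on this read-out lower numbers stand for stronger inhibition and higher numbers for weaker inhibition. Among the compounds with values here, compound 1 stands at the highest of the two numbers; its only neighbour is compound 2, reached by a 2.6-fold lower number from compound 1 to compound 2 (0.41 log units; beyond the scatter), a modest gain that lies beyond the scatter. Compound 3 `CCOC(=O)N1N=C(c2ccc(O)c(OC)c2)CC1c1ccccc1` has not yet been measured. It differs from compound 1 by ethoxy in place of phenyl on a carbonyl carbon; cut one bond further out, the change reads benzoyl to ethoxycarbonyl. Within the data shown here, no measured step bears directly on this change: the one known step, from compound 1 to compound 2, exchanges the whole group on the ring nitrogen for a different one and so gives no guide to putting ethoxy in place of phenyl on the carbonyl carbon. With nothing to lean on, no step beyond the scatter is expected in this assay, in either direction, and the range is kept wide. Compound 3 is therefore expected to give 50000 nM, between 17000 nM and 150000 nM, which amounts to an expected step of a 1.2-fold higher number from compound 1 to compound 3 (0.09 log units; within the scatter).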

Compound 3, inhibition constant: 201000 nM
Compound 3: middle estimate off by 4.0-fold (0.60 log units), on the low side, outside the stated range (above it).
By their numbers in this assay, from the lowest: compound 2; then compound 1; then compound 3.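

In this assay, the carbonyl stays in place and only what it carries changes, yet ethoxy in place of phenyl on the carbonyl carbon gives a clear loss (a 4.9-fold higher number from compound 1 to compound 3 (0.69 log units; beyond the scatter)), so the phenyl is not a neutral part of this group. Exchanging the whole group on the ring nitrogen gives a larger shift (a 13-fold higher number from compound 2 to compound 3 (1.10 log units; beyond the scatter)), and in these three compounds the two groups holding a six-membered aromatic ring both stand at lower numbers than ethoxycarbonyl, which has no ring. No measurement here explains why the number rises with this change.

From the compounds shown here alone, whether the aromatic ring itself matters, or only the size of the group, stays open. Cyclohexyl, benzyl or a longer chain on the same carbonyl carbon could help separate these two readings.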